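The compounds below may be only part of what the source reports. "The series", "measured", "known", "first", "only" and "open" are said of these compounds alone.

Working notes on the series. The shared core of compound 1 `Nc1cc(N)c2nc(-c3ccccc3)c(NCc3ccc(Cl)c(Cl)c3)nc2c1` is kept throughout; compound 1 carries a 3,4-dichlorobenzylamine and in a functional assay on MOLT-4 cells (Homo sapiens) for inhibition, read by sulforhodamine B assay, with a stated time of 48 h (on this read-out lower numbers stand for stronger inhibition of growth and higher numbers for weaker inhibition of growth), compound 1 gives 2090 nM. Compound 3 `COc1cc(CNc2nc3cc(N)cc(N)c3nc2-c2ccccc2)cc(OC)c1OC` carries a trimethoxybenzylamine in the same position and in this assay compound 3 gives 12300 nM. Compound 2 `Nc1cc(N)c2nc(-c3ccccc3)c(Sc3ccc(F)cc3)nc2c1` replaces the benzylamine with a (4-fluorophenyl)sulfanyl group. For compound 2 this assay reports only a limit, < 100000 nM, so no number is known for compound 2 the limit of < 100000 nM in this assay, at which 1 of the 3 values shown sits, and compound 2 stands apart from the two numbered values without a position of its own among them.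

Compound 4 `COc1ccc(Sc2nc3cc(N)cc(N)c3nc2-c2ccccc2)cc1` differs from compound 2 in one place: methoxy in place of fluoro on an aromatic carbon. For the measured compounds named here, no step between measured compounds involves this change, and compound 2 itself supplies only a limit, so the size of the step from compound 2 to compound 4 in this assay cannot be read from the data; the step is expected to be small and no direction is expected beyond the scatter, as a step that the limit leaves unreadable from compound 2 to compound 4. Compound 4 is therefore estimated at 50000 nM, with a range from 10000 nM to 100000 nM.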

Compound 4, concentration for 50% growth inhibition: 4170 nM
Compound 4: the middle estimate sits 12-fold (1.08 log units) above what was measured, and the stated range ends above it.
By their numbers in this assay, from the lowest: compounds 1 and 4 (each within the scatter of the next); then compound 3.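

No step from compound 2 to compound 4 can be read in this assay, as compound 2 has only a limit: the limit of < 100000 nM in this assay, at which 1 of the 4 values shown sits.

The compounds shown leave open the size and direction of the change from fluoro to methoxy on an aromatic carbon, since no pair with two numbered values carries it.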